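Cyclopentenyl for Chlorophenyl: a Step Off the Aryl Series

A few compounds are considered here, and "the series" means these few. Any claim that something is new, unique, unknown or untested is made for them only; others in the source may bear on it.

Compound 1 `O=C(O)c1csc(-n2nc(-c3ccc(F)cc3)c3ccccc32)n1` gives 4.5 nM in an assay on isolated protein for antagonist activity at prostaglandin E2 receptor EP1 subtype (Homo sapiens), read by reporter gene assay; on this read-out lower numbers stand for stronger inhibition and higher numbers for weaker inhibition.
Compound 2 `O=C(O)c1csc(-n2nc(-c3ccc(Cl)cc3)c3ccccc32)n1` gives 12 nM in this assay.
Compound 3 `O=C(O)c1csc(-n2nc(-c3ccc(C(F)(F)F)cc3)c3ccccc32)n1` gives 140 nM in this assay.

Compound 2 stands second highest of the three numbers; compound 1 lies a 2.7-fold higher number from compound 1 to compound 2 (0.43 log units; beyond the scatter) away, and compound 3 sits further off, a 12-fold higher number from compound 2 to compound 3 (1.07 log units; beyond the scatter). Compound 4 `O=C(O)c1csc(-n2nc(C3=CCCC3)c3ccccc32)n1` is not yet measured. It differs from compound 2 by cyclopent-1-en-1-yl in place of 4-chlorophenyl on an aromatic carbon. Among the measured compounds shown here, no measured step exchanges the whole ring; the known steps, a 2.7-fold higher number from compound 1 to compound 2 (0.43 log units; beyond the scatter), a 31-fold higher number from compound 1 to compound 3 (1.49 log units; beyond the scatter) and a 12-fold higher number from compound 2 to compound 3 (1.07 log units; beyond the scatter), only swap the group on the aromatic ring, where a larger group gave a higher number. The change to compound 4 is therefore only loosely anchored; a moderate rise, a 2.9-fold higher number from compound 2 to compound 4 (0.46 log units; beyond the scatter), is expected, with wide uncertainty. Compound 4 is estimated at 35 nM, between 7 nM and 250 nM.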

Compound 4, half-maximal inhibitory concentration: 80 nM
Compound 4: middle estimate off by 2.3-fold (0.36 log units), on the low side, within the range that was stated.
By their numbers in this assay, from the lowest: compound 1; then compound 2; then compounds 4 and 3 (each within the scatter of the next).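

Exchanging the whole aryl ring at this position raises the number without abolishing activity: in this assay the change brings a 6.7-fold higher number from compound 2 to compound 4 (0.82 log units; beyond the scatter) and also an 18-fold higher number from compound 1 to compound 4 (1.25 log units; beyond the scatter). An aromatic ring on this carbon is thus not essential, since the non-aromatic five-membered carbon ring of cyclopent-1-en-1-yl retains measurable inhibition. Nothing available explains the loss. The compounds shown leave open whether the double bond matters, which a saturated cyclopentyl ring would test, and whether a cyclohexenyl ring or a ring carrying an ether oxygen or an amine would be tolerated here.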